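This account rests on a few compounds, and the source may have more. Where it says the series, first, only, none or still open, it means among the compounds named here.

Measured compounds:
compound 1, `CC1=C(C(=O)NC(C)C)C(c2ccco2)NC(=O)N1`, 2% in an assay on membranes from HEK293 cells for displacement of a labelled ligand from adenosine receptor A2b (Homo sapiens), read by scintillation counting, with a stated time of 30 min, tested at 1 uM; on this read-out lower numbers stand for less inhibition and higher numbers for more inhibition at the one concentration tested (going by the name of the read-out)
compound 2, `CCN(CC)C(=O)C1=C(C)NC(=O)NC1c1ccco1`, 31%
compound 3, `CCSC(=O)C1=C(C)NC(=O)NC1c1ccco1`, 29%

Among these three numbers, compound 3 stands second highest: it sits close to compound 2, with a number 2 percentage points lower from compound 2 to compound 3 (within the scatter), and well apart from compound 1, with a number 27 percentage points higher from compound 1 to compound 3 (beyond the scatter). The whole series keeps the same shared core and varies only the group on the carbonyl carbon.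

Compound 4, `CCC(CC)OC(=O)C1=C(C)NC(=O)NC1c1ccco1`, is not yet measured. It differs from compound 3 by (pentan-3-yl)oxy in place of ethylsulfanyl on a carbonyl carbon. Among the compounds with values here, three measured steps bear on this: a number 29 percentage points higher from compound 1 to compound 2 (beyond the scatter) and a number 27 percentage points higher from compound 1 to compound 3 (beyond the scatter) show that moving away from isopropylamino raised the number, while a number 2 percentage points lower from compound 2 to compound 3 (within the scatter) shows that swapping diethylamino for ethylsulfanyl changed nothing beyond the scatter. The new group is again not isopropylamino, so for compound 4 no step beyond the scatter is expected, a number 4 percentage points lower from compound 3 to compound 4 (within the scatter). The estimate for compound 4 is 25%, with an expected range from 5% to 45%.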

Compound 4, a percentage reported as inhibition, at one concentration (the size of the read-out at that concentration, not a potency): 35%
Beside the measured number, compound 4's estimate is 10 percentage points below it; measured number inside the range.
By their numbers in this assay, from the lowest: compound 1; then compounds 3, 2 and 4 (each within the scatter of the next).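

In this assay, the group on the carbonyl carbon grows from ethylsulfanyl, with 3 heavy atoms, to (pentan-3-yl)oxy, with 6 heavy atoms, and this gives a number 6 percentage points higher from compound 3 to compound 4 (within the scatter). The comparison with the amide gives a number 4 percentage points higher from compound 2 to compound 4 (within the scatter), so a branched group joined through oxygen reads like the groups joined through sulfur or through the nitrogen of diethylamino. Isopropylamino remains the one group apart among these four, with a number 33 percentage points higher from compound 1 to compound 4 (beyond the scatter).

The data shown give no reason why these three groups read alike or why isopropylamino differs. Going by these compounds, it stays open whether a smaller group such as methoxy, a cyclic amine such as pyrrolidine or a free carboxylic acid at this carbonyl would read like these three groups or like isopropylamino.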